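The compounds below may be only part of what the source reports. "The series", "measured", "known", "first", "only" and "open" are said of these compounds alone.

Compound 1 `O=C(COc1ccc(Br)cc1)Nc1nc(-c2ccc(Br)cc2)cs1` gives 41700 nM in a functional assay on Ehrlich cells (Mus musculus) for cytotoxicity, read by MTT assay, with a stated time of 48 h; a lower number here means a stronger inhibitor, a higher number a weaker inhibitor.
Compound 2 `O=C(COc1ccccc1)Nc1nc(-c2ccc(Br)cc2)cs1` gives 37200 nM in this assay.
Compound 3 `Cc1ccccc1OCC(=O)Nc1nc(-c2ccc(Br)cc2)cs1` gives 44900 nM in this assay.

All three compounds share a core and differ only in the group attached to the oxygen on a saturated carbon. Compound 3 stands with its two neighbours: the change a 1.1-fold higher number from compound 1 to compound 3 (0.03 log units; within the scatter) and the change a 1.2-fold higher number from compound 2 to compound 3 (0.08 log units; within the scatter) both fall within the scatter, so nothing separates these three values. Compound 4 `Cc1ccc(OCC(=O)Nc2nc(-c3ccc(Br)cc3)cs2)cc1` is the next member: 4-methylphenyl in place of 2-methylphenyl on an oxygen on a saturated carbon. The steps that changed this same aryl group, from compound 1 to compound 3 and from compound 2 to compound 3, each stayed within the scatter, so no shift beyond the scatter is expected here either, and the estimated step of a 1.1-fold lower number from compound 3 to compound 4 (0.03 log units; within the scatter) is small. Compound 4 is estimated at 42000 nM, within a range of 20000 nM to 90000 nM.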

Compound 4, half-maximal inhibitory concentration: 55800 nM
For compound 4 the middle estimate is 1.3-fold (0.12 log units) below the measured one; measured number inside the range.
By their numbers in this assay, from the lowest: compounds 2, 1, 3 and 4 (each within the scatter of the next).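

The methyl group can sit in either named place on the phenyl without the number leaving the scatter (a 1.2-fold higher number from compound 3 to compound 4 (0.09 log units; within the scatter)). In this assay, the same holds when 4-methylphenyl is compared with the unsubstituted phenyl (a 1.5-fold higher number from compound 2 to compound 4 (0.18 log units; within the scatter)) and with 4-bromophenyl (a 1.3-fold higher number from compound 1 to compound 4 (0.13 log units; within the scatter)). Across these four compounds, then, neither the place of the methyl nor a swap among hydrogen, methyl and bromo separates the values.

No measurement here explains this flat result. As far as these compounds go, whether a carboxylic acid or an amine on this phenyl would move the number beyond the scatter remains open.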